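A few compounds are considered here, and "the series" means these few. Any claim that something is new, unique, unknown or untested is made for them only; others in the source may bear on it.

Compound 1 `COc1ccc2nc(N(Cc3cc(-c4ccc(SC(F)(F)F)cc4)no3)c3nc4ccc(F)cc4s3)sc2c1` gives 26500 nM in a functional assay on A549 cells (Homo sapiens) for antiproliferative activity, read by MTT assay; on this read-out lower numbers stand for stronger inhibition and higher numbers for weaker inhibition.
Compound 2 `COc1ccc(-c2cc(CN(c3nc4ccc(F)cc4s3)c3nc4ccc(OC)cc4s3)on2)cc1` gives 38800 nM.
Compound 3 `FC(F)(F)Sc1ccc(-c2cc(CN(c3ncccn3)c3nc4ccccc4s3)on2)cc1` gives 29800 nM.

All three numbers sit close together: compound 3 lies within the scatter of compound 1 and of compound 2, so no one of them can be called more or less potent than another. Going by the values given here, the only single-point step among them, a 1.5-fold higher number from compound 1 to compound 2 (0.17 log units; within the scatter), swaps the same (trifluoromethyl)sulfanyl group that is now in question.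

Compound 4 `Brc1ccc(-c2cc(CN(c3ncccn3)c3nc4ccccc4s3)on2)cc1` differs from compound 3 by bromo in place of (trifluoromethyl)sulfanyl on an aromatic carbon. Among the compounds with values here, the one step that bears on this place, from compound 1 to compound 2, stayed within the scatter, so for compound 4 a change no larger than the scatter is expected: a 1.0-fold higher number from compound 3 to compound 4 (0.00 log units; within the scatter). Compound 4 is therefore estimated at 30000 nM, with a range from 12000 nM to 75000 nM.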

Compound 4, half-maximal inhibitory concentration: 31500 nM
Estimate against measurement, compound 4: 1.1-fold (0.02 log units) below; the range from low to high includes it.
By their numbers in this assay, from the lowest: compounds 1, 3, 4 and 2 (each within the scatter of the next).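

In this assay, bromo in place of (trifluoromethyl)sulfanyl gives a 1.1-fold higher number from compound 3 to compound 4 (0.02 log units; within the scatter) on the shared core. This adds a second exchange at this position, on a different core from the earlier step, and one heavy atom in place of five still leaves the number within the scatter. Nothing measured here offers a reason for this. The three groups shown at this position, (trifluoromethyl)sulfanyl, methoxy and bromo, leave open whether an amine or a carboxylic acid there would move the number beyond the scatter.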